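Ring size at the thiocarbonyl: the pyrrolidine analogue

This account rests on a few compounds, and the source may have more. Where it says the series, first, only, none or still open, it means among the compounds named here.

Measured so far in a functional assay on A-431 cells (Homo sapiens) for cytotoxicity, read by MTT assay, with a stated time of 72 h, tested at 10 uM; a higher number here means more inhibition of growth at the concentration tested, a lower number less inhibition of growth:
- compound 1 `N/C(=N\NC(=S)N1CCOCC1)c1ccccn1` gives 69.4%
- compound 2 `N/C(=N\NC(=S)N1CCSCC1)c1ccccn1` gives 61.4%
- compound 3 `N/C(=N\NC(=S)N1CCCCC1)c1ccccn1` gives 68.1%

Compound 3 stands second highest of the three numbers; its nearest neighbour is compound 1, its furthest is compound 2, and both gaps lie within the scatter. The next member, compound 4 `N/C(=N\NC(=S)N1CCCC1)c1ccccn1`, is not yet measured. It differs from compound 3 in one place: pyrrolidin-1-yl in place of piperidin-1-yl on a thiocarbonyl carbon.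

The steps measured so far all swap one six-membered ring for another on the thiocarbonyl carbon: a number 8 percentage points lower from compound 1 to compound 2 (within the scatter), a number 1.3 percentage points lower from compound 1 to compound 3 (within the scatter) and a number 6.7 percentage points higher from compound 2 to compound 3 (within the scatter), each within the scatter. None of them changes the size of the ring, so they bear on the present step only indirectly; what they show is that the three ring variants so far give numbers close to one another in this assay. On that basis no step beyond the scatter is expected from compound 3 to compound 4, with the estimated step being a number 2.1 percentage points lower from compound 3 to compound 4 (within the scatter). Compound 4 is expected to give about 66%, within a range of 52% to 80%.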

Compound 4, percent growth inhibition at one concentration: 77.2%
Estimate against measurement, compound 4: 11.2 percentage points below; low and high end bracket the measured number.
By their numbers in this assay, from the lowest: compounds 2, 3, 1 and 4 (each within the scatter of the next, the first and the last beyond it).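

In this assay, going by these compounds alone, the first change of ring size on the thiocarbonyl carbon, pyrrolidin-1-yl in place of piperidin-1-yl, gives (a number 9.1 percentage points higher from compound 3 to compound 4 (within the scatter)), and the same five-membered ring in place of morpholin-4-yl gives (a number 7.8 percentage points higher from compound 1 to compound 4 (within the scatter)), so neither comparison separates the five-membered ring from these six-membered rings. Against thiomorpholin-4-yl, however, the series shows its first step beyond the scatter, a modest one (a number 15.8 percentage points higher from compound 2 to compound 4 (beyond the scatter)), which makes the choice of ring on this carbon measurable for this one pair only. No measured evidence on why these numbers differ is available here.

Going by these compounds, it remains open whether the trend with ring size extends to the smaller azetidin-1-yl or the larger azepan-1-yl ring. Also open, on these data alone, is how an open-chain dimethylamino group or a piperazin-1-yl ring would compare on the same carbon.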